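From 3-hydroxyphenyl to 3-chlorophenyl at the limit

This account rests on a few compounds, and the source may have more. Where it says the series, first, only, none or still open, it means among the compounds named here.

compound 1 `COc1ccc(-c2cnc(NC(=O)c3ccc(Br)cc3)n2C)cc1` gives > 100000 nM
compound 2 `COc1ccc(-c2cnc(NC(=O)CCc3ccccc3)n2C)cc1` gives > 100000 nM
compound 3 `COc1ccc(-c2cnc(NC(=O)c3cccc(O)c3)n2C)cc1` gives > 100000 nM

These entries come from a toxicity assay on THP-1 cells (Homo sapiens) for inhibition (on this read-out higher numbers stand for lower toxicity in this test and lower numbers for higher toxicity in this test), and each is a limit, not a number. Compound 3 stands at > 100000 nM, a limit. The series offers the limit of > 100000 nM in this assay, at which 3 of the 3 values shown sit, as its whole picture so far. Compound 4 `COc1ccc(-c2cnc(NC(=O)c3cccc(Cl)c3)n2C)cc1` differs in one place: chloro in place of hydroxy on an aromatic carbon, with chloro in place of hydroxy on an aromatic carbon. Among the measured compounds shown here, two measured steps bear on it, a step that the two limits leave unreadable from compound 1 to compound 3 and a step that the two limits leave unreadable from compound 2 to compound 3, and neither yields a size. Compound 1, with its 4-bromophenyl group, is likewise a limit at > 100000 nM. No step beyond the scatter is therefore expected in this assay. The estimated change is a number no higher from compound 3 to compound 4 (the limit leaves the size open). The estimated value for compound 4 is 100000 nM, with an expected range from 40000 nM to 100000 nM.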

Compound 4, half-maximal cytotoxic concentration: > 28000 nM
Compound 4: only a limit was reported; the forecaster's own chance of this, stated with the estimate: 80%; the middle value lies beyond the limit too.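

In this assay compound 4 gives > 28000 nM, which is a limit. Among the compounds shown here, compound 1, compound 2 and compound 3 are limits too, so no step to compound 4 can be read. The compounds shown leave open whether any of these changes alters the half-maximal cytotoxic concentration at all.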